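This account rests on a few compounds, and the source may have more. Where it says the series, first, only, none or still open, it means among the compounds named here.

Three compounds have been run in a functional assay on HeLa cells (Homo sapiens) for antiproliferative activity, read by sulforhodamine B assay, with a stated time of 48 h; a higher number here means a weaker inhibitor of growth, a lower number a stronger inhibitor of growth. Compound 1 `O=c1c2ccc(C(F)(F)F)nc2ncn1Cc1cc(-c2ccc(Cl)cc2)no1` gives 840 nM, compound 2 `CCCCCCCCCCn1cc(Cn2c(-c3ccco3)nc3nc(C(F)(F)F)ccc3c2=O)nn1` gives 870 nM, and compound 3 `O=C(Cn1cc(COc2nc(-c3ccccc3)nc3nc(C(F)(F)F)ccc23)nn1)Nc1ccccc1` gives 890 nM. Compound 3 thus holds the highest of the three numbers, but its gaps to compound 2 and to compound 1 both lie within the scatter, so the three cannot be ranked. Among the compounds with values here, no pair among them differs in one place, so the effect of a single change is unknown. Compound 4 `COc1cc(-n2cc(COc3nc(-c4ccccc4)nc4nc(C(F)(F)F)ccc34)nn2)cc(OC)c1OC` differs from compound 3 by 3,4,5-trimethoxyphenyl in place of (phenylcarbamoyl)methyl on an aromatic nitrogen. Within the data shown here, with no measured step to draw on, the step expected from compound 3 to compound 4 in this assay is a 1.0-fold higher number from compound 3 to compound 4 (0.00 log units; within the scatter), none beyond the scatter in either direction. Compound 4 is therefore estimated at 900 nM in this assay, with a range from 300 nM to 2700 nM.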

Compound 4, concentration for 50% growth inhibition: 890 nM
Beside the measured number, compound 4's estimate is 1.0-fold (0.00 log units) above it, within the range that was stated.
By their numbers in this assay, from the lowest: compounds 1, 2, 3 and 4 (each within the scatter of the next).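

Within the data shown here, this is the first single-place step: 3,4,5-trimethoxyphenyl in place of (phenylcarbamoyl)methyl on the aromatic nitrogen gives no change at the digits printed from compound 3 to compound 4 (within the scatter) in this assay. At this position, the amide hydrogen and the carbonyl leave and three methoxy groups enter with no step beyond the scatter, so this one exchange does not separate the two groups. No measurement bears on why the two groups read alike.

Still open, on these data alone, is whether a carboxylic acid or an amine at this nitrogen would read the same. One pair also leaves open whether the same exchange behaves alike on other cores.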